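This account rests on a few compounds, and the source may have more. Where it says the series, first, only, none or still open, it means among the compounds named here.

Compound 1, `C#CCSc1cnc2ccccc2c1[Se]CC#CCCl`, in a functional assay on T47D cells (Homo sapiens) for antiproliferative activity, with a stated time of 72 h (on this read-out higher numbers stand for weaker inhibition and lower numbers for stronger inhibition), gives 0.4 ug/mL.
Compound 2, `OCC#CCSc1cnc2ccccc2c1SCC#CCCl`, gives 5.3 ug/mL.
Compound 3, `CSc1cnc2ccccc2c1SCC#CCOC(=O)/C=C/c1ccccc1`, gives 71.9 ug/mL.

Of these three, compound 3 stands at the highest number, and its steps to the other two both lie beyond the usual scatter: compound 2 sits closest to it, and compound 1 furthest away, so compound 3 is the weakest inhibitor of the set on this read-out.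

Compound 4, `CCOC(=O)OCC#CCSc1c(SC)cnc2ccccc12`, has not yet been measured. It differs from compound 3 in a single spot: ethoxy in place of 2-phenylethenyl on a carbonyl carbon. The rest of the molecule, including the methylthio group on the shared core and the chain carrying the carbonyl, is unchanged.

For the measured compounds named here, no measured pair shows a step of this kind, so there is no direct guide to its size. Since the two compounds with chloro-substituted chains, compound 1 and compound 2, give the lower numbers while compound 3 with the larger ester end gives the highest, a modest move toward stronger inhibition from compound 3 to compound 4 is expected, about a 1.8-fold lower number from compound 3 to compound 4 (0.25 log units; within the scatter), though it may stay within the scatter. Compound 4 in this assay is accordingly estimated at 40 ug/mL, with a likely range from 10 ug/mL to 150 ug/mL.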

Compound 4, concentration for 50% inhibition: 34.2 ug/mL
For compound 4 the middle estimate is 1.2-fold (0.07 log units) above the measured one; measured number inside the range.
By their numbers in this assay, from the lowest: compound 1; then compound 2; then compound 4; then compound 3.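

In this assay, for the compounds shown here, ethoxy in place of 2-phenylethenyl on the carbonyl carbon gives a 2.1-fold lower number from compound 3 to compound 4 (0.32 log units; beyond the scatter) and so provides the first step in the set that changes one place only. It shows that this end of the chain affects the read-out, and that giving up the six-membered aromatic ring and the double bond, going from 8 heavy atoms to 3, brings a modest move toward stronger inhibition rather than a loss. The data offer no measured explanation for this step.

The ring and the double bond leave together, so their shares in the step cannot be told apart, and a 2-phenylethyl or a plain phenyl group on the same carbonyl carbon would separate them. On these data alone, how a methoxy group, a tert-butoxy group or an amine would compare with ethoxy at this place also remains open.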